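The source may hold more compounds than are shown below. What is called first, only, known or untested is meant among the compounds shown, and "the series" means these compounds.

Compound 1 `O=C(CCl)Nc1ccc(C(=O)/C=C/c2ccccc2Cl)cc1`: 6980 nM
Compound 2 `Cc1ccc(/C=C/C(=O)c2ccc(NC(=O)CCl)cc2)cc1`: 7150 nM

Both numbers come from a functional assay on EC9706 cells (Homo sapiens) for cytotoxicity, read by MTT assay, with a stated time of 72 h; on this read-out lower numbers stand for stronger inhibition and higher numbers for weaker inhibition. For the measured compounds named here, compound 1 has only one neighbour on this scale, and the two values cannot be told apart: the step is a 1.0-fold higher number from compound 1 to compound 2 (0.01 log units; within the scatter). That step swaps in 4-methylphenyl for 2-chlorophenyl, so it concerns a different part of the molecule.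

Compound 3 `O=C(CSC(=S)N[C@H]1CCOC1=O)Nc1ccc(C(=O)/C=C/c2ccccc2Cl)cc1` keeps the core of compound 1 but carries a much larger change: a group of 10 heavy atoms (5 carbon, 1 nitrogen, 2 oxygen, 2 sulfur; one five-membered non-aromatic ring with 1 hetero atom) in place of one chlorine atom, on a saturated chain carbon bound to a carbonyl carbon. Going by the values given here, no measured compound shows what any change at this saturated chain carbon does, so the one available step gives neither size nor direction. It shows only that one substitution elsewhere on the core left the number within the scatter. A replacement this large could move the value either way, so the expectation stays close to compound 1, leaning only slightly towards a lower number, with a wide margin. The estimated step is a 2.0-fold lower number from compound 1 to compound 3 (0.30 log units; within the scatter). For compound 3 the expected value is 3500 nM, with an estimated range of 600 nM to 15000 nM.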

Compound 3, half-maximal inhibitory concentration: 34100 nM
Compound 3: middle estimate off by 9.7-fold (0.99 log units), on the low side; measured number outside the range, above it.
By their numbers in this assay, from the lowest: compounds 1 and 2 (each within the scatter of the next); then compound 3.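

The saturated chain carbon bound to a carbonyl carbon now has its first reading in this assay: replacing the chlorine atom with the group of 10 heavy atoms gives a 4.9-fold higher number from compound 1 to compound 3 (0.69 log units; beyond the scatter). Thus, unlike the swap of 2-chlorophenyl for 4-methylphenyl, this change moves the number measurably, and in the direction of weaker inhibition, with compound 3 at 34100 nM. No measurement is at hand that accounts for this step, so it cannot be assigned to the five-membered ring, the sulfur atoms, the defined stereocentre or the overall count of heavy atoms.

With only one replacement at this carbon, the compounds shown give no trend and do not reveal how much of the step belongs to each part of the entering group. An amine or a short thioether chain in place of the chlorine atom could help separate those parts, while the same large group on the core of compound 2 would test whether the step carries over to the 4-methylphenyl series.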